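A Methoxy Added to Compound 2

A few compounds are considered here, and "the series" means these few. Any claim that something is new, unique, unknown or untested is made for them only; others in the source may bear on it.

Measured so far in a functional assay for inhibition, with Rattus norvegicus as the target; on this read-out lower numbers stand for stronger inhibition and higher numbers for weaker inhibition:
- Compound 1 `CCCCc1c(CCCC)c(OC(C)=O)c2ccccc2c1OC`: 6020 nM
- Compound 2 `CCCCc1cc(OC)c2ccccc2c1OC(C)=O`: 440 nM
- Compound 3 `CCCCc1cc(OC)c2ccccc2c1O`: 1470 nM

Of these three, compound 2 has the lowest number, 440 nM, and the gaps to the other two lie beyond the scatter. Compound 4 `CCCCc1cc(OC)c2ccc(OC)cc2c1OC(C)=O` keeps the structure of compound 2 except for one change: methoxy in place of hydrogen on an aromatic carbon. In words, this is methoxy in place of hydrogen on an aromatic carbon.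

Within the data shown here, no measured step makes this exact change, so the evidence is indirect. The nearest parallel is a 14-fold lower number from compound 1 to compound 2 (1.14 log units; beyond the scatter), a large step in which hydrogen replaces butyl on an aromatic carbon. Read in reverse, it shows a higher number for the compound with the extra group, but butyl is not methoxy. The other step, a 3.3-fold higher number from compound 2 to compound 3 (0.52 log units; beyond the scatter), is modest and concerns the acetyl on oxygen, which compound 4 retains, so it bears on this change only weakly.

A modest rise in the number in this assay is therefore expected, with considerable uncertainty. The expected step is a 1.6-fold higher number from compound 2 to compound 4 (0.20 log units; within the scatter). For compound 4 the estimated value is 700 nM, with an expected range from 200 nM to 2500 nM.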

Compound 4, half-maximal inhibitory concentration: 1380 nM
Compound 4: the middle estimate sits 2.0-fold (0.29 log units) below what was measured; low and high end bracket the measured number.
By their numbers in this assay, from the lowest: compound 2; then compounds 4 and 3 (each within the scatter of the next); then compound 1.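

In this assay, methoxy in place of hydrogen on this aromatic carbon, meta to a fused ring and para to a fused ring, gives a 3.1-fold higher number from compound 2 to compound 4 (0.50 log units; beyond the scatter), a modest step that lies beyond the scatter. The earlier steps shown here concerned only a butyl on an aromatic carbon and the acetyl on oxygen, so this result adds a direct reading at a different place: here an added group of 2 heavy atoms, with no ring and no net charge, is enough to raise the number measurably. The data at hand offer no measurement that would explain why the number rises with this change.

Going by these compounds, whether fluorine, hydroxy, ethoxy or an amine on the same aromatic carbon would move the number in the same direction and by a similar amount remains open, as does the effect of methoxy on the other aromatic carbons of that ring. On these data alone, it is also open whether the same methoxy would produce a comparable step on compound 3, which has hydrogen in place of the acetyl on oxygen.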